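This account rests on a few compounds, and the source may have more. Where it says the series, first, only, none or still open, it means among the compounds named here.

Values in a functional assay for antagonist activity, with Cavia porcellus as the target (on this read-out lower numbers stand for stronger inhibition and higher numbers for weaker inhibition), so far:
- compound 1 `COc1ccc(N(C)CC#CCCC2SCCCS2)cc1OC` gives 2220 nM
- compound 2 `CN(CC#CCCC1SCCCS1)Cc1ccc2ccccc2c1` gives 8330 nM
- compound 3 `CN(CC#CCCC1(C(O)(c2ccccc2)c2ccccc2)SCCCS1)Cc1ccccc1` gives 3170 nM

Compound 3 at 3170 nM cannot be separated within the usual scatter from compound 1 at 2220 nM on these numbers. Compound 2 at 8330 nM stands beyond the scatter on the weaker side of compound 3.

Compound 4 `OC(c1ccccc1)(c1ccccc1)C1(CCC#CCN2CCCCC2)SCCCS1` has not yet been measured. Its difference from compound 3 is piperidin-1-yl in place of benzyl(methyl)amino on a saturated chain carbon bound to a triple-bonded carbon and the rest of the structure stays the same. In words, piperidin-1-yl takes the place of benzyl(methyl)amino on a saturated chain carbon bound to a triple-bonded carbon.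

Going by the values given here, no two measured compounds differ in one place, so the data give no direct size for such a step in this assay. A small move towards stronger inhibition is expected, probably not beyond the scatter, and this direction is a tentative call. The estimate expects a 1.8-fold lower number from compound 3 to compound 4 (0.25 log units; within the scatter) as the step. For compound 4 the estimated value is 1800 nM with an expected range from 350 nM to 7000 nM in this assay.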

Compound 4, antagonist equilibrium constant: 1000 nM
Compound 4: the middle estimate sits 1.8-fold (0.26 log units) above what was measured; measured number inside the range.
By their numbers in this assay, from the lowest: compound 4; then compounds 1 and 3 (each within the scatter of the next); then compound 2.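

In this assay, going by these compounds alone, this is the first single change that can be read: piperidin-1-yl in place of benzyl(methyl)amino, on a saturated chain carbon bound to a triple-bonded carbon, gives a 3.2-fold lower number from compound 3 to compound 4 (0.50 log units; beyond the scatter), a step beyond the scatter. With the rest of compound 3 unchanged, the six-membered aromatic ring of the benzyl group is therefore not required at this place for the inhibition seen, and a smaller group with a non-aromatic ring gives the lower number. Nothing at hand explains the step.

Open, as far as these compounds go, is whether a smaller ring such as pyrrolidin-1-yl or an open-chain dimethylamino group would lower the number further at this place. Also open, from the compounds shown here alone, is whether morpholin-4-yl, with a ring oxygen, would keep the value of compound 4.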